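Swapping a pyrrole for a methylpyrazole on a fused core

The source may hold more compounds than are shown below. What is called first, only, known or untested is meant among the compounds shown, and "the series" means these compounds.

Measured compounds:
- compound 2, `COc1ccc2c(OCc3nnc4sc(-c5cc[nH]c5)nn34)ccnc2c1`: 353 nM
- compound 1, `COc1ccc2c(OCc3nnc4sc(-c5cccn5C)nn34)ccnc2c1`: "not determined" (no result reported)

In a functional assay on EBC-1 cells (Homo sapiens) for antiproliferative activity, with a stated time of 72 h (a higher number here means a weaker inhibitor, a lower number a stronger inhibitor), compound 2 gives 353 nM. Within the data shown here, this is the only number in the set; compound 1 carries "not determined" (no result reported), so nothing can be said about how compound 1 compares with compound 2.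

Compound 3, `COc1ccc2c(OCc3nnc4sc(-c5cnn(C)c5)nn34)ccnc2c1`, has not yet been measured. It differs from compound 2 in one place: 1-methyl-1H-pyrazol-4-yl in place of 1H-pyrrol-3-yl on an aromatic carbon. The rest of the molecule, the shared core with its methoxy-bearing fused ring system and the ether link, stays the same.

Among the measured compounds shown here, no measured pair shows what such a swap does here, so the expectation for compound 3 rests on compound 2 alone, which gives 353 nM. A group of similar size and shape on the same carbon is expected to keep the potency in the same region, so the estimated step of a 1.4-fold lower number from compound 2 to compound 3 (0.15 log units; within the scatter) is expected to stay within or only just beyond the usual scatter. For compound 3, the expected value in this assay is 250 nM, with a plausible range from 60 nM to 1000 nM.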

Compound 3, half-maximal inhibitory concentration: 88 nM
Compound 3: middle estimate off by 2.8-fold (0.45 log units), on the high side, and the stated range covers the measured number.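

In this assay, among these compounds, the first readable step at this position is a 4.0-fold lower number from compound 2 to compound 3 (0.60 log units; beyond the scatter), so the aromatic carbon next to the ring sulfur responds to the choice of five-membered ring and does not merely tolerate any group of similar size. The change also shows that potency here does not depend on a hydrogen-bond donor on this ring: 1H-pyrrol-3-yl has 1 such donor and 0 acceptors, whereas the stronger 1-methyl-1H-pyrazol-4-yl has 0 donors and 2 acceptors. Nothing available explains why this swap lowers the number.

As far as these compounds go, this single pair changes several things at once, as the ring gains a second nitrogen, loses its hydrogen-bond donor and gains a methyl group, so the share of each in the step remains unknown. An unsubstituted 1H-pyrazol-4-yl would help to separate the methyl group from the ring, while an ethyl group or a longer chain ending in an amine on the same pyrazole nitrogen would show how far this position can be extended.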